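Working notes: from butyl to iodo in the series

The source may report more compounds than this note shows. Statements on the series, on what has been measured and on what is new or still open speak of the compounds shown alone.

In a functional assay on M21 cells (Homo sapiens) for antiproliferative activity, read by sulforhodamine B assay, with a stated time of 48 h (a higher number here means a weaker inhibitor, a lower number a stronger inhibitor), compound 1 (`Cc1cccc(NS(=O)(=O)c2ccc(N3CCNC3=O)cc2)c1`) gives 69 nM, and compound 2 (`CCCCc1ccc(NS(=O)(=O)c2ccc(N3CCNC3=O)cc2)cc1`) gives 450 nM. Compound 2 therefore holds the higher of the two numbers, which makes it the weaker inhibitor of the pair, and its gap to compound 1 lies beyond the usual scatter. Among the measured compounds shown here, no measured pair differs in one place only.

The next entry is compound 3 (`O=C1NCCN1c1ccc(S(=O)(=O)Nc2ccc(I)cc2)cc1`), with iodo in place of butyl on an aromatic carbon, para to a large group: iodo in place of butyl on an aromatic carbon. For the measured compounds named here, no measured step isolates this change, so the expectation rests on just two values and stays wide. Going by the values given here, compound 1 at 69 nM shows only that a clearly lower number is reachable on the shared core in this assay. A moderate move towards a lower number is expected, and the estimated change is a 2.3-fold lower number from compound 2 to compound 3 (0.35 log units; beyond the scatter). For compound 3 the expected value is 200 nM, with an estimated range of 70 nM to 600 nM.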

Compound 3, half-maximal inhibitory concentration: 260 nM
Compound 3: middle estimate off by 1.3-fold (0.11 log units), on the low side; the measured number falls inside the stated range.
By their numbers in this assay, from the lowest: compound 1; then compounds 3 and 2 (each within the scatter of the next).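

Butyl and iodo on this aromatic carbon, para to a large group, give numbers that cannot be told apart in this assay (a 1.7-fold lower number from compound 2 to compound 3 (0.24 log units; within the scatter)), so a single iodine here reads the same as a chain of four carbons, which the earlier pair could not show. The second step (a 3.8-fold higher number from compound 1 to compound 3 (0.58 log units; beyond the scatter)) lies beyond the scatter, but it sets 4-iodophenyl against 3-methylphenyl on the sulfonamide nitrogen, so both the group and its place on the ring differ and the gap cannot be assigned to either one alone. No supporting data accompany these numbers, so they remain a bare reading of the assay with no account of what lies behind them.

Open, going by these compounds, is how an ethyl chain, an amine or a carboxylic acid would read on the same aromatic carbon, and so whether the match between butyl and iodo extends to other groups. Also open, on these data alone, is whether iodo, set where compound 1 carries its methyl, would stay near the number of compound 1 (69 nM), which would separate the effect of the group from that of its place.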